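The source may report more compounds than this note shows. Statements on the series, on what has been measured and on what is new or still open speak of the compounds shown alone.

Working notes on the series in a functional assay on A549 cells (Homo sapiens) for cytotoxicity, read by MTT assay, with a stated time of 72 h; a lower number here means a stronger inhibitor, a higher number a weaker inhibitor.

Of the compounds shown here, two of the shared core have numbers so far. Compound 1 `COc1cc2c(Oc3ccc(NC(=O)c4cn(-c5ccccc5Cl)nn4)cc3F)ccnc2cc1OCCCN1CCCC1` gives 330 nM. Compound 2 `COc1cc2c(Oc3ccc(NC(=O)c4cn(-c5ccccc5)nn4)cc3F)ccnc2cc1OCCCN1CCC(C)CC1` gives 140 nM, the lowest of the two numbers; compound 1 stands a fair distance above it, beyond the usual scatter. The two differ in more than one place, so no single step can be read between them.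

Compound 3 `COc1cc2c(Oc3ccc(NC(=O)c4cn(-c5ccccc5Cl)nn4)cc3F)ccnc2cc1OCCCN1CCC(C)CC1` is not yet measured. It differs from compound 2 by chloro in place of hydrogen on an aromatic carbon. Among the measured compounds shown here, no measured pair isolates this change, so its effect is unknown from the data at hand. The numbers of compound 1 and compound 2 at least do not point to a large shift from a chloro-bearing ring alone. A step in this assay of about a 1.4-fold higher number from compound 2 to compound 3 (0.15 log units; within the scatter) is expected, not clearly beyond the scatter, if anything toward a slightly higher number. For compound 3 the estimate is 200 nM, with a range from 80 nM to 500 nM.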

Compound 3, half-maximal inhibitory concentration: 370 nM
Estimate against measurement, compound 3: 1.9-fold (0.27 log units) below; low and high end bracket the measured number.
By their numbers in this assay, from the lowest: compound 2; then compounds 1 and 3 (each within the scatter of the next).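

In this assay, among the compounds shown here, with 4-methylpiperidin-1-yl held fixed, chloro in place of hydrogen on the phenyl ring gives a 2.6-fold higher number from compound 2 to compound 3 (0.42 log units; beyond the scatter) as the first isolated reading of this change, a modest loss at this position ortho to a large group. With the 2-chlorophenyl group held fixed, 4-methylpiperidin-1-yl in place of pyrrolidin-1-yl gives a 1.1-fold higher number from compound 1 to compound 3 (0.05 log units; within the scatter) and so shows no effect that can be separated from the scatter. No measurement at hand accounts for the chloro step.

As far as these compounds go, whether the chloro step also holds with pyrrolidin-1-yl on the chain remains open. Also open, from the compounds shown here alone, is how fluoro, methyl or methoxy in the same place on the ring would compare with chloro and hydrogen.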